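This account rests on a few compounds, and the source may have more. Where it says the series, first, only, none or still open, it means among the compounds named here.

Compound 1 `COc1ccc(N2CCN(C(=S)SCc3ccc4nc(N)nc(N)c4c3)CC2)cc1`: 1660 nM
Compound 2 `Nc1nc(N)c2cc(CSC(=S)N3CCN(c4ccc(F)cc4)CC3)ccc2n1`: 1840 nM

In a functional assay on HeLa cells (Homo sapiens) for antiproliferative activity, read by MTT assay, with a stated time of 72 h (on this read-out higher numbers stand for weaker inhibition and lower numbers for stronger inhibition), compound 2 gives 1840 nM, level with compound 1 within the scatter. Compound 3 `Nc1nc(N)c2cc(CSC(=S)N3CCN(c4ccc([N+](=O)[O-])cc4)CC3)ccc2n1` carries nitro in place of fluoro on an aromatic carbon, para to a large group: nitro in place of fluoro on an aromatic carbon. Among the measured compounds shown here, the only measured step bearing on this change is fluoro in place of methoxy on an aromatic carbon: a 1.1-fold higher number from compound 1 to compound 2 (0.04 log units; within the scatter). For the measured compounds named here, no nitro compound has yet been measured, so no step beyond the scatter is expected in this assay. The estimated step is a 1.0-fold lower number from compound 2 to compound 3 (0.01 log units; within the scatter). The expected value for compound 3 is 1800 nM, with an estimated range of 700 nM to 4500 nM.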

Compound 3, half-maximal inhibitory concentration: 1660 nM
Compound 3: the middle estimate sits 1.1-fold (0.04 log units) above what was measured; low and high end bracket the measured number.
By their numbers in this assay, from the lowest: compounds 1, 3 and 2 (each within the scatter of the next).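

Within this assay nitro in place of fluoro on the aromatic carbon para to a large group leaves the reading level (a 1.1-fold lower number from compound 2 to compound 3 (0.04 log units; within the scatter)), and nitro in place of methoxy does the same (no change at the digits printed from compound 1 to compound 3 (within the scatter)). Among the compounds shown here, three different groups at this position now show no separation, so the flat reading extends beyond the single fluoro-for-methoxy comparison. No supporting measurement accounts for this flat reading.

As far as these compounds go, whether an amine, a carboxylic acid or a plain hydrogen at this position would separate from these three remains open. So does whether changes elsewhere on the shared core would move the number.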